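The compounds below may be only part of what the source reports. "The series", "measured", "known", "first", "only" and "open" are said of these compounds alone.

Working notes on the series. Compound 1 `O=S(=O)(/C=C\c1ncccc1F)c1cccc(Cl)c1` and compound 2 `O=S(=O)(/C=C\c1ncccc1Cl)c1cccc(Cl)c1` share a core and differ in a single place; compound 3 `O=S(=O)(/C=C\c1cccnc1Cl)c1ccccc1F` is built from the same atoms as compound 1 joined differently, and the difference between the two cores is not broken down here. In an assay on U2OS cells for activation of nuclear factor erythroid 2-related factor 2 (Homo sapiens), read by beta-arrestin recruitment, with a stated time of 6 h (a lower number here means that less compound is needed, a higher number that more compound is needed for the effect), compound 1 gives 252 nM, compound 2 gives 290 nM, and compound 3 gives 3390 nM, the highest number of the three measured compounds. The step of a 1.2-fold higher number from compound 1 to compound 2 (0.06 log units; within the scatter) goes with the change (chloro in place of fluoro on an aromatic carbon).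

Compound 4 `O=S(=O)(/C=C\c1cccnc1Cl)c1ccccc1Cl` has not yet been measured in this assay. It differs from compound 3 by chloro in place of fluoro on an aromatic carbon. This is the same kind of change as that from compound 1 to compound 2, not the same one: there the ring carries one nitrogen and the site is two atoms from the ring nitrogen, here the ring is of carbon only; in both cases the site is ortho to a large group. Among the compounds shown the change occurs twice, once measured. Since a 1.2-fold higher number from compound 1 to compound 2 (0.06 log units; within the scatter) lay within the scatter, a step of like size is expected for compound 4: a 1.2-fold higher number from compound 3 to compound 4 (0.06 log units; within the scatter). Compound 4 is accordingly estimated at 3900 nM in this assay, with a likely range from 1900 nM to 8000 nM. The measurement will show whether the change on the ring of carbon only behaves as it did on the ring with one nitrogen.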

Compound 4, half-maximal effective concentration: 384 nM
For compound 4 the middle estimate is 10-fold (1.01 log units) above the measured one, outside the stated range (below it).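

In this assay, chloro in place of fluoro on an aromatic carbon of the ring of carbon only gives an 8.8-fold lower number from compound 3 to compound 4 (0.95 log units; beyond the scatter), whereas the same kind of change on the ring with one nitrogen gave a 1.2-fold higher number from compound 1 to compound 2 (0.06 log units; within the scatter). The size of this step therefore did not carry from the core of compound 1 to the core of compound 3, and the two steps differ by more than repeated measurement would account for: the same change on two cores in this assay, a 1.2-fold higher number (0.06 log units; within the scatter) from compound 1 to compound 2 and an 8.8-fold lower number (0.95 log units; beyond the scatter) from compound 3 to compound 4, 10-fold (1.01 log units) apart, beyond the scatter of two such steps This shows that the step measured on one core cannot serve as a reliable estimate on the other, but it does not show which structural difference between the cores, or which site of the change, sets the size of the step, and two pairs establish no general rule for either ring.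

The compounds shown leave open whether bromo, methyl, methoxy or nitrile at the site changed between compound 3 and compound 4 would give a step like that of chloro. They also leave open how the same replacement of fluoro by chloro would behave on further cores, so neither of the two steps can yet be called typical of the series.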